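Naphthalenyl in Place of Methoxyphenoxy on the Shared Core

The source may report more compounds than this note shows. Statements on the series, on what has been measured and on what is new or still open speak of the compounds shown alone.

Measured compounds:
compound 1, `FC(F)(F)c1ccc(-c2ccc3c(NCCCNCc4ccco4)ccnc3c2)cc1`: 3470 nM
compound 2, `c1ccc(Oc2ccc3c(NCCCNCc4ccco4)ccnc3c2)cc1`: 15200 nM
compound 3, `COc1ccccc1Oc1ccc2c(NCCCNCc3ccco3)ccnc2c1`: 6500 nM

In an ADME assay on HepG2 cells (Homo sapiens) for cytotoxicity, read by luminescence, CellTiter-Glo and ATP content, with a stated time of 72 h (on this read-out higher numbers stand for an effect only at larger amounts of compound and lower numbers for an effect already at smaller amounts), compound 3 stands second highest of the three numbers; its nearest neighbour is compound 1, since a 1.9-fold higher number from compound 1 to compound 3 (0.27 log units; within the scatter), while the gap to compound 2 is larger, a 2.3-fold lower number from compound 2 to compound 3 (0.37 log units; beyond the scatter). Compound 4, `c1coc(CNCCCNc2ccnc3cc(-c4cccc5ccccc45)ccc23)c1`, is not yet measured. It differs from compound 3 in one place: naphthalen-1-yl in place of 2-methoxyphenoxy on an aromatic carbon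

Among the measured compounds shown here, two measured steps bear on this change. The step of a 4.4-fold higher number from compound 1 to compound 2 (0.64 log units; beyond the scatter) shows that replacing a directly attached aryl group by an ether-linked phenyl group raised the number, and a 1.9-fold higher number from compound 1 to compound 3 (0.27 log units; within the scatter) shows that the methoxy-bearing ether stayed close to the aryl compound. Compound 4 returns to a directly attached aryl group, as in compound 1, so a number near compound 1 or somewhat lower is expected, and the step of a 2.0-fold lower number from compound 3 to compound 4 (0.31 log units; beyond the scatter) is expected to run downward, modestly. Compound 4 is therefore estimated at 3200 nM, within a range from 1100 nM to 9500 nM.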

Compound 4, half-maximal effective concentration: 5600 nM
Compound 4: the middle estimate sits 1.8-fold (0.24 log units) below what was measured; low and high end bracket the measured number.
By their numbers in this assay, from the lowest: compounds 1, 4 and 3 (each within the scatter of the next); then compound 2.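

In this assay, the position on the shared core tolerates the loss of 2-methoxyphenoxy, with its oxygen atoms and hydrogen-bond acceptors, and the entry of naphthalen-1-yl, with its two six-membered aromatic rings of carbon only, without a change beyond the scatter (a 1.2-fold lower number from compound 3 to compound 4 (0.06 log units; within the scatter)). The larger aryl group also stays within the scatter of the 4-(trifluoromethyl)phenyl group of compound 1 (a 1.6-fold higher number from compound 1 to compound 4 (0.21 log units; within the scatter)), while the plain phenoxy group of compound 2 stands apart from naphthalen-1-yl (a 2.7-fold lower number from compound 2 to compound 4 (0.43 log units; beyond the scatter)), so among these four compounds an oxygen link at this position does not by itself separate the numbers: compound 3 carries such a link and goes against that reading. Nothing available here accounts for why compound 2 alone stands apart.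

On these data alone, it remains open whether a basic ring such as pyridin-3-yl, or a carboxylic acid on the attached aryl group, would move the number at this position. The four compounds also keep the same propane chain and furan-2-ylmethyl amine throughout, so they cannot tell whether a longer chain would leave these small differences as they stand.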